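Could one group swap change strong plasma binding?

This account rests on a few compounds, and the source may have more. Where it says the series, first, only, none or still open, it means among the compounds named here.

Compound 1 `O=C(Nc1ccc2ccccc2c1)NC1CCN(C/C2=C/CCCCCC2)CC1`: > 99.9% (a limit of the assay, not a number)
Compound 2 `CC1(C)[C@H]2CC=C(CN3CCC(NC(=O)Nc4cc(C(F)(F)F)cc(C(F)(F)F)c4)CC3)[C@@H]1C2`: 99.9%

Among the compounds with values here, in an ADME assay on a cell-free system (plasma, Homo sapiens) for binding affinity, with Plasma (Rattus norvegicus) as the target, compound 2 gives 99.9% as the only true number so far. Compound 3 `CC(C)(C)C(=O)N1CCC(CN2CCC(NC(=O)Nc3cc(C(F)(F)F)cc(C(F)(F)F)c3)CC2)CC1` is still unmeasured and differs from compound 2 in one group: a group of 12 heavy atoms (10 carbon, 1 nitrogen, 1 oxygen; one six-membered non-aromatic ring with 1 hetero atom) in place of a group of 9 heavy atoms (9 carbon; one four-membered non-aromatic ring of carbon only, one six-membered non-aromatic ring of carbon only), on a saturated chain carbon bound to an amine nitrogen in a ring. Within the data shown here, no measured step yet shows what such a swap does. With compound 2 at 99.9% little room remains upward in this assay so a small fall is expected rather than a rise. The expected step runs an 8.0-fold higher unbound fraction from compound 2 to compound 3 (0.90 log units; beyond the scatter) and stays modest. For compound 3 the estimated value is 99.2% with 97% to 99.9% as the expected range.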

Compound 3, plasma protein binding in the Plasma assay: 99%
The estimate for compound 3 lay 1.3-fold (0.10 log units) (unbound fraction) below the measured number; measured number inside the range.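

In the Plasma assay, putting 1-((tert-butyl)carbonyl)piperidin-4-yl in place of the all-carbon group, on a saturated chain carbon bound to an amine nitrogen in a ring, gives a 10-fold higher unbound fraction from compound 2 to compound 3 (1.00 log units; beyond the scatter), so this position can shift binding. The same swap also changes a physicochemical assay for lipophilicity, at pH 7.4 (on this read-out lower numbers stand for lower lipophilicity and higher numbers for higher lipophilicity), where compound 2 gives 5.1 and compound 3 gives 4.2, so lower lipophilicity travels with the freer fraction: the measured distribution coefficient of compound 2, 5.1, and of compound 3, 4.2, a number 0.90 log units lower (beyond the scatter) Even so, in the Plasma assay compound 3 still gives 99%, so little of it is free.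

One step cannot separate the effect of the carbonyl from that of the ring change. As far as these compounds go, whether an amine or a carboxylic acid at this place would free more compound remains open.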